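This account rests on a few compounds, and the source may have more. Where it says the series, first, only, none or still open, it means among the compounds named here.

Compound 3, `COc1ccc(Sc2nc3cc(N)cc(N)c3nc2-c2ccccc2)cc1`, belongs to a small set of three compounds that share one core and differ in the group hung from it. Compound 1, `CCOC(=O)[C@H](CCC(=O)O)NC(=O)c1ccc(CNc2nc3cc(N)cc(N)c3nc2-c2ccccc2)cc1`, in a functional assay on NCI-H522 cells (Homo sapiens) for inhibition, read by sulforhodamine B assay, with a stated time of 48 h (a higher number here means that more compound is tolerated, a lower number that less compound is tolerated), gives only a limit, < 100000 nM. Compound 2, `COc1ccc(CNc2nc3cc(N)cc(N)c3nc2-c2ccccc2)cc1`, in this assay gives a measured number, 47900 nM. Compound 3 in this assay likewise gives only a limit, < 100000 nM. So compound 3 stands on no number at all, only on the limit, and the evidence across the set is thin: the limit of < 100000 nM in this assay, at which 2 of the 3 values shown sit, so that only compound 2 supplies a real value.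

The step to compound 4, `Nc1cc(N)c2nc(-c3ccccc3)c(Sc3ccc(F)cc3)nc2c1`, is a single change on the outer ring: fluoro in place of methoxy on an aromatic carbon. Within the data shown here, no step between two measured compounds is available to calibrate what this change does in this assay.

Compound 4 is therefore expected to sit close to where compound 2 sits, around 50000 nM, with a range from 15000 nM to 100000 nM. The step from compound 3 to compound 4 is expected to be a step that the limit leaves unreadable from compound 3 to compound 4, that is, nothing beyond the usual scatter, with a fair chance that compound 4 again returns only a limit rather than a number.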

Compound 4, concentration lethal to 50% of the cells: < 100000 nM
Compound 4 was reported as a limit; the forecaster's own chance of this, stated with the estimate: 40%; the middle value does not contradict the limit.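

No step can be read from compound 3 to compound 4, because each of the two is reported only as a limit: the limit of < 100000 nM in this assay, at which 3 of the 4 values shown sit.

The compounds shown leave open whether fluoro in place of methoxy on an aromatic carbon alters the result in this assay at all, and in which direction.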